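This account rests on a few compounds, and the source may have more. Where it says the series, first, only, none or still open, it means among the compounds named here.

Measured compounds:
Compound 1 `CC(C)(C)c1ccc(CNCCCNS(=O)(=O)c2cc(C(F)(F)F)cc(C(F)(F)F)c2)cc1` — 2900 nM
Compound 2 `O=S(=O)(NCCCNCc1ccc(Cl)c(C(F)(F)F)c1)c1cc(C(F)(F)F)cc(C(F)(F)F)c1` — 5900 nM

In a functional assay on A2780 cells (Homo sapiens) for inhibition, read by MTT assay, with a stated time of 72 h (a higher number here means a weaker inhibitor of growth, a lower number a stronger inhibitor of growth), compound 1 gives 2900 nM, the lowest of the two numbers; the nearest neighbour is compound 2, at 5900 nM. Among the compounds with values here, the one measured step, a 2.0-fold higher number from compound 1 to compound 2 (0.31 log units; beyond the scatter), replaces the aryl group on the chain carbon bound to the amine nitrogen and weakens growth inhibition modestly.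

Compound 3 `O=S(=O)(NCCCNCc1ccc(-c2ccccc2)cc1)c1cc(C(F)(F)F)cc(C(F)(F)F)c1` differs from compound 1 by phenyl in place of tert-butyl on an aromatic carbon, at a position described as para to a large group. Within the data shown here, no measured pair matches this change directly; the step from compound 1 to compound 2 bears on it only in showing that altering the same aryl end moves this assay by a modest amount. A phenyl replacing a tert-butyl is expected to give a step of similar or smaller size, in either direction, and most likely within the scatter: a 1.2-fold higher number from compound 1 to compound 3 (0.08 log units; within the scatter).

Compound 3 is therefore estimated at 3500 nM in this assay, within a range from 1200 nM to 10000 nM.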

Compound 3, concentration for 50% growth inhibition: 2600 nM
Compound 3: the middle estimate sits 1.3-fold (0.13 log units) above what was measured, and the stated range covers the measured number.
By their numbers in this assay, from the lowest: compounds 3 and 1 (each within the scatter of the next); then compound 2.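

In this assay, putting phenyl in place of tert-butyl gives a 1.1-fold lower number from compound 1 to compound 3 (0.05 log units; within the scatter), so the two compounds cannot be told apart in this assay. The earlier step showed only that a different substituted aryl end moved the number modestly, whereas this one shows that, on this aromatic carbon para to a large group, a tert-butyl of 4 heavy atoms can give way to a phenyl of 6 heavy atoms, with its six-membered aromatic ring, and leave growth inhibition within the scatter. Nothing in the material shown accounts for this result.

From the compounds shown here alone, whether a carboxylic acid or an amine on this same aromatic carbon would also leave the number within the scatter remains open. So does the effect of a longer chain in place of the saturated chain in the shared core.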